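Direct Aryl Replaces the Benzyloxy Arm on the Shared Core

A few compounds are considered here, and "the series" means these few. Any claim that something is new, unique, unknown or untested is made for them only; others in the source may bear on it.

Compound 1, `Cc1nn(-c2ncnc3nc[nH]c23)c2c1C(OCc1ccccc1C#N)CC(=O)N2`, gives 127 nM in a functional assay on HEK293 cells for agonist activity at G-protein coupled receptor 39 (Homo sapiens), read by scintillation proximity assay and inositol phosphate accumulation, with a stated time of 75 min; a higher number here means that more compound is needed for the effect, a lower number that less compound is needed.
Compound 2, `Cc1nn(-c2ncnc3nc[nH]c23)c2c1C(OCCn1cccn1)CC(=O)N2`, gives 2270 nM in this assay.
Compound 3, `CCC(C(=O)NC1CC(=O)Nc2c1c(C)nn2-c1ncnc2nc[nH]c12)c1ccccc1`, gives 79 nM in this assay.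

Compound 1 stands second highest of the three numbers. Compound 3 is its nearest neighbour, and the two values lie within the scatter of each other. Among the compounds with values here, compound 2 is the furthest: an 18-fold higher number from compound 1 to compound 2 (1.25 log units; beyond the scatter) is the one measured step that changes a single place, and it is large.

Compound 4, `Cc1nn(-c2ncnc3nc[nH]c23)c2c1C(c1ccc(F)cc1Cl)CC(=O)N2`, keeps the shared core of compound 1 and changes one place: 2-chloro-4-fluorophenyl in place of (2-cyanobenzyl)oxy on a saturated ring carbon

Within the data shown here, no measured step bears directly on this change. The step from compound 1 to compound 2 keeps the oxygen and the chain and only exchanges what hangs on them, whereas compound 4 removes the oxygen and the chain and puts the aromatic ring straight onto the saturated ring carbon. Compound 3 shows that a quite different side chain on that carbon can land within the scatter of compound 1. Compound 4 is therefore expected to show no step beyond the scatter, a 1.2-fold higher number from compound 1 to compound 4 (0.07 log units; within the scatter), with a wide range to allow for the missing comparison. The estimate for compound 4 is 150 nM, between 30 nM and 800 nM.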

Compound 4, half-maximal effective concentration: 280 nM
Estimate against measurement, compound 4: 1.9-fold (0.27 log units) below; the range from low to high includes it.
By their numbers in this assay, from the lowest: compounds 3 and 1 (each within the scatter of the next); then compound 4; then compound 2.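

The result shows that the saturated ring carbon does not need the oxygen and chain of compounds 1 and 2 to give agonist activity in this assay: an aromatic ring bound directly to that carbon still gives a finite half-maximal effective concentration. The direct exchange for the (2-cyanobenzyl)oxy group is a modest step in the unfavourable direction (a 2.2-fold higher number from compound 1 to compound 4 (0.34 log units; beyond the scatter)), whereas the exchange for the 2-(1H-pyrazol-1-yl)ethoxy group runs the other way (an 8.1-fold lower number from compound 2 to compound 4 (0.91 log units; beyond the scatter)), so the 2-chloro-4-fluorophenyl compound falls within the span set by those two ether side chains rather than outside it. (Nothing given here explains either step).

The compounds shown leave open how much of these steps belongs to the removal of the oxygen and chain and how much to the chlorine and fluorine on the new ring, a question that an unsubstituted phenyl on the same carbon would address. Also open, going by these compounds, is how an amine, a carboxylic acid or a longer chain on that saturated ring carbon would read in this assay.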